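A few compounds are considered here, and "the series" means these few. Any claim that something is new, unique, unknown or untested is made for them only; others in the source may bear on it.

In an assay for inhibition of Thromboxane-A synthase (Homo sapiens), using microsomes (on this read-out higher numbers stand for weaker inhibition and lower numbers for stronger inhibition), compound 2 `O=C(O)CC/C=C\C[C@@H]1CO[C@H](CCCCCOc2cc(C(=O)O)ccc2OCCn2ccnc2)O[C@@H]1c1ccccc1O` gives 60 nM and compound 1 `O=C(O)CC/C=C\C[C@@H]1CO[C@H](c2ccc(OCCn3ccnc3)c(C(=O)O)c2)O[C@@H]1c1ccccc1O` gives 3800 nM. Compound 3 `O=C(O)CC/C=C\C[C@@H]1CO[C@H](c2cncc(/C(=C/CCCCC(=O)O)c3ccccc3)c2)O[C@@H]1c1ccccc1O` yields no number in this assay, only the limit > 10000 nM. That limit is the one at which (the limit of > 10000 nM in this assay, at which 1 of the 3 values shown sits). Compound 3 therefore stands at the weak end of the three values shown, with no measured figure of its own to work from.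

Compound 4 `O=C(O)CC/C=C\C[C@@H]1CO[C@H](c2cncc(/C(=C\CCCCC(=O)O)c3ccccc3)c2)O[C@@H]1c1ccccc1O` is the geometric isomer of compound 3: the two compounds have the same atoms and bonds and differ only in configuration as drawn: 1 of 5 stereo elements differ; a double bond is drawn E in compound 3 and Z in compound 4. Within the data shown here, no pair of compounds with measured numbers differs in that way alone, so there is no measured step to set the size of this change against, and the other two compounds differ from compound 3 in far more than the double bond. Because compound 3 sits at the limit > 10000 nM, a move to stronger inhibition in this assay cannot be excluded, but a change of geometry alone is not expected to carry the compound close to where compound 2 stands. Compound 4 is therefore estimated at about 8000 nM in this assay, within the range 1500 nM to 30000 nM. The step this estimate implies, an at least 1.2-fold lower number from compound 3 to compound 4 (0.09 log units; that floor lies within the scatter), is expected to be small and quite possibly to leave compound 4 also reported only as a limit.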

Compound 4, half-maximal inhibitory concentration: > 10000 nM
Compound 4 gave a limit, no number (the forecaster's own chance of this, stated with the estimate: 40%); at least 1.2-fold (0.09 log units) between middle value and limit.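

In this assay compound 4 gives only a limit (> 10000 nM) and no number. Compound 3 also stands at a limit, so no step can be read between compound 3 and compound 4: the limit of > 10000 nM in this assay, at which 2 of the 4 values shown sit. The compounds shown leave open whether the double-bond geometry changes inhibition at all: the fact that compounds 3 and 4 differ only in the configuration as drawn.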